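One more chloro on compound 2

A few compounds are considered here, and "the series" means these few. Any claim that something is new, unique, unknown or untested is made for them only; others in the source may bear on it.

Results so far in a functional assay on HeLa cells (Homo sapiens) for antiproliferative activity, read by MTT assay, with a stated time of 48 h (a lower number here means a stronger inhibitor, a higher number a weaker inhibitor), for two compounds
compound 1 `Clc1cc2nc(-c3cn(-c4ccccc4)nc3-c3ccccc3)[nH]c2cc1Cl` gives 13400 nM
compound 2 `Clc1ccc(-c2nn(-c3ccccc3)cc2-c2nc3cc(Cl)ccc3[nH]2)cc1` gives 1630 nM

Of these two numbers, compound 2 has the lower, so it is the stronger inhibitor of the pair. The gap between the two compounds lies beyond the usual scatter of repeated measurements. They are not, however, a clean comparison of one change, so that gap cannot be tied to any single group.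

Compound 3 `Clc1ccc(-c2nn(-c3ccccc3)cc2-c2nc3cc(Cl)c(Cl)cc3[nH]2)cc1` comes from compound 2 through one change chloro in place of hydrogen on an aromatic carbon in which chloro takes the place of hydrogen on an aromatic carbon, ortho to a chloro group. Going by the values given here, no measured pair here differs in one place only, so the size of this step rests on judgement rather than precedent. In this assay a small move towards a lower number is expected, quite possibly none beyond the scatter. The estimate implies a 1.5-fold lower number from compound 2 to compound 3 (0.17 log units; within the scatter) as the expected change. Compound 3 is expected at 1100 nM with a likely range from 350 nM to 3500 nM once measured.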

Compound 3, half-maximal inhibitory concentration: 12100 nM
Beside the measured number, compound 3's estimate is 11-fold (1.04 log units) below it; measured number above the stated range.
By their numbers in this assay, from the lowest: compound 2; then compounds 3 and 1 (each within the scatter of the next).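

In this assay, a chloro placed on the six-membered aromatic ring of the fused system, ortho to a chloro group, is far from a neutral addition: a 7.4-fold higher number from compound 2 to compound 3 (0.87 log units; beyond the scatter), so this single heavy atom is enough to weaken the compound beyond the scatter. With two chloro groups already on that ring, the chloro on another aromatic carbon makes no difference beyond the scatter, as a 1.1-fold lower number from compound 1 to compound 3 (0.04 log units; within the scatter) shows, which leaves compound 2, with its single chloro on that ring, apart from the other two compounds. No measurement here offers an explanation for this drop.

Going by these compounds, whether fluoro, methoxy or an amine on that same carbon would give a number nearer that of compound 2 or that of compound 3 remains open. Also open is whether the chloro on the other aromatic carbon matters when the fused ring carries only one chloro: the compounds shown hold no such pair.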